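Swapping an amide substituent in pyrazole carboxylic acid analogues

The compounds below may be only part of what the source reports. "The series", "measured", "known", "first", "only" and "open" are said of these compounds alone.

Measured so far:
Compound 1, `Cc1n[nH]c(C(=O)O)c1Cc1ccc(-c2ccc(F)cc2)cc1`, gives 11%.
Compound 2, `Cc1n[nH]c(C(=O)O)c1Cc1ccc(-c2ccc(C(F)(F)F)cc2)cc1`, gives 5%.
Compound 3, `Cc1n[nH]c(C(=O)NS(C)(=O)=O)c1Cc1cccc(-c2ccc(F)cc2)c1`, gives 8%.

In an assay on isolated protein for inhibition of 2-Hydroxyacid oxidase 2 (Homo sapiens), tested at 1 uM (on this read-out higher numbers stand for a stronger effect at the one concentration tested and lower numbers for a weaker effect), all three numbers sit close together. Compound 3 lies in the middle of the three, within the scatter of compound 1 and of compound 2, so no ordering among them can be claimed. For the measured compounds named here, the one step that can be followed, a number 6 percentage points lower from compound 1 to compound 2 (within the scatter), stays within the scatter as well.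

Compound 4, `CNC(=O)c1[nH]nc(C)c1Cc1cccc(-c2ccc(F)cc2)c1`, has not yet been measured. It differs from compound 3 in one place: methyl in place of methylsulfonyl on an amide-type nitrogen. Going by the values given here, no measured pair shows this change, so the step from compound 1 to compound 2 cannot be carried over to it directly; it only tells that a change on the outer aromatic ring left the read-out within the scatter. Without a comparable step, the expectation for compound 4 is a number near that of compound 3, with a number 1 percentage points lower from compound 3 to compound 4 (within the scatter) expected to stay within the scatter. Compound 4 is therefore estimated at 7%, in the range -5% to 20%.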

Compound 4, a percentage reported as inhibition, at one concentration (the size of the read-out at that concentration, not a potency): 7%
Estimate against measurement, compound 4: no gap at the digits printed, and the stated range covers the measured number.
By their numbers in this assay, from the lowest: compounds 2, 4, 3 and 1 (each within the scatter of the next).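

In this assay, for the compounds shown here, the first step that can be followed on the amide-type nitrogen is a number 1 percentage points lower from compound 3 to compound 4 (within the scatter). Methylsulfonyl, with 4 heavy atoms, and methyl, with 1 heavy atom, therefore cannot be told apart here, even though this is a much larger swap in size than the change on the outer aromatic ring seen earlier. Going by these compounds alone, with a single concentration and a read-out this small, this shows only that the swap leaves the number within the scatter, and nothing available explains that result.

From the compounds shown here alone, whether any group at this nitrogen can lift the read-out clear of the scatter remains open, for example a longer chain such as butyl or a chain ending in an amine. Also open, going by these compounds, is whether the same swap would behave alike with the outer aromatic ring placed as in compound 1.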